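The compounds below may be only part of what the source reports. "The series", "measured", "known", "first", "only" and "open" are said of these compounds alone.

In a functional assay on M21 cells (Homo sapiens) for antiproliferative activity, with a stated time of 48 h (a lower number here means a stronger inhibitor, a higher number a weaker inhibitor), compound 1 `CCCCC(O)c1cccc(NC(=O)NC(=O)CC)c1` gives > 100000 nM, a limit of the assay and not a number. Compound 2 `CCCCC(OC)c1cccc(NC(=O)NC(=O)CC)c1` gives > 100000 nM, also a limit. Compound 2 therefore has no exact position on the scale, and the whole record so far is the limit of > 100000 nM in this assay, at which 2 of the 2 values shown sit. For the measured compounds named here, the only measured step, a step that the two limits leave unreadable from compound 1 to compound 2, has no size to carry forward. Compound 3 `C=CC(=O)Nc1cccc(C(CCCC)OC)c1` differs from compound 2 in another place: vinyl in place of propanoylamino on a carbonyl carbon. Going by the values given here, no measured step covers this change, so any expectation here is loose. In this assay the expected outcome is a modest move toward a lower number, meaning a stronger inhibitor, or else no readable change at all. The expected step is an at least 2.0-fold lower number from compound 2 to compound 3 (0.30 log units; that floor lies within the scatter). For compound 3 the estimated value is 50000 nM, with an expected range from 15000 nM to 150000 nM.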

Compound 3, half-maximal inhibitory concentration: 48000 nM
For compound 3 the middle estimate is 1.0-fold (0.02 log units) above the measured one; the measured number falls inside the stated range.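

In this assay, vinyl in place of propanoylamino on a carbonyl carbon gives an at least 2.0-fold lower number from compound 2 to compound 3 (0.31 log units; beyond the scatter), so this position can move the read-out, and the true step may be larger, as only its lower bound can be read. The step from compound 1 to compound 2 cannot be read, which makes this the first change shown with a readable size and compound 3 the first compound with a real number. Compound 1 and compound 2 remain limits and not numbers: the limit of > 100000 nM in this assay, at which 2 of the 3 values shown sit.

The compounds shown leave open whether vinyl itself matters or only the loss of propanoylamino, a question that ethyl or a longer chain on that carbonyl carbon would address. Also open, from the compounds shown here alone, is whether methyl in place of hydrogen on the oxygen makes any difference once vinyl is present.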